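Swapping Fluoro for Cyano on Compound 1

The compounds below may be only part of what the source reports. "The series", "measured", "known", "first", "only" and "open" are said of these compounds alone.

Going by the values given here, only two compounds have numbers so far. In a functional assay on Jurkat cells (Homo sapiens) for cytotoxicity, read by luminescence and CellTiter-Glo, with a stated time of 3 days (on this read-out lower numbers stand for stronger inhibition and higher numbers for weaker inhibition), compound 1 (`N#Cc1ccc(NC(=O)c2ccc3cccnc3c2O)c(F)c1`) gives 420 nM and compound 2 (`N#Cc1ccc(NC(=O)c2cc(Br)c3cccnc3c2O)cc1`) gives 230 nM on the same read-out, so the two lie within the usual scatter of each other. Among the compounds with values here, compound 1 therefore cannot be told apart from the only other measured compound. These two also differ in more than one place, which leaves no single change to learn from.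

Compound 3 (`N#Cc1ccc(NC(=O)c2ccc3cccnc3c2O)c(C#N)c1`) is compound 1 with one swap (counted: cyano in place of fluoro on an aromatic carbon), cyano in place of fluoro on an aromatic carbon. This carbon is ortho to a large group and meta to a cyano group. Within the data shown here, no measured pair shows what such a swap does in this assay or which way it would push the number, so the expectation has to stay modest. The expected size of the step of a 1.1-fold higher number from compound 1 to compound 3 (0.03 log units; within the scatter) lies inside the scatter, with no direction favoured. For compound 3 the estimated value is 450 nM with 150 nM to 1400 nM as the expected range.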

Compound 3, half-maximal inhibitory concentration: 270 nM
Beside the measured number, compound 3's estimate is 1.7-fold (0.22 log units) above it, within the range that was stated.
By their numbers in this assay, from the lowest: compounds 2, 3 and 1 (each within the scatter of the next).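

In this assay, going by these compounds alone, cyano in place of fluoro on an aromatic carbon gives a 1.6-fold lower number from compound 1 to compound 3 (0.19 log units; within the scatter), the first change at a single place that can be read in this set. The carbon in question is ortho to a large group and meta to a cyano group, and the result shows that these two groups at this carbon cannot be told apart on this read-out, even though the cyano group is counted with more heavy atoms and a hydrogen-bond acceptor that fluoro lacks. No separate measurement bears on this result, so the number alone offers no explanation for it.

Both groups give numbers within the scatter of each other. One step says little about how much this carbon matters overall, and it does not show whether any other group would shift the number clearly. Within the data shown here, an amine, a methoxy group or a plain hydrogen at the same carbon would test this more widely, and a step beyond the scatter would be the first sign that the group at this place affects the read-out.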